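The source may report more compounds than this note shows. Statements on the series, on what has been measured and on what is new or still open speak of the compounds shown alone.

Working notes on the bromoacrylamide series.

Of the compounds shown here, three have been measured in a functional assay on CCRF-CEM cells (Homo sapiens) for cytotoxicity, read by cell counting, with a stated time of 3 days; a lower number here means a stronger inhibitor, a higher number a weaker inhibitor. Compound 1 `C=C(Br)C(=O)Nc1cccc(/C=C2\SC(=O)N(Cc3ccc(C)cc3)C2=O)c1` gives 1200 nM, and compound 2 `C=C(Br)C(=O)Nc1ccc(/C=C2\SC(=O)N(Cc3cccc(Cl)c3)C2=O)cc1` gives 3700 nM. Compound 3 `Nc1cccc(/C=C2\SC(=O)N(Cc3cccc(Cl)c3)C2=O)c1`, which lacks the bromoacrylamide, gives 195000 nM. On these numbers compound 2 stands second highest of the three: its gap to compound 1 lies beyond the scatter, and its gap to compound 3 is far beyond it. For the measured compounds named here, no pair among the measured compounds differs in a single place, so no clean step is on hand.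

Compound 4 `C=C(Br)C(=O)Nc1ccc(/C=C2\SC(=O)N(C)C2=O)cc1` is the next to be measured in this assay. Relative to compound 2 the change is hydrogen in place of 3-chlorophenyl on a saturated chain carbon bound to an amide-type nitrogen in a ring. Going by the values given here, nothing among the measured compounds isolates this change, so the expectation rests on the retained bromoacrylamide, which in compound 2 goes with 3700 nM, and on the loss of the larger substituent. A step from compound 2 to compound 4 of a 2.4-fold higher number from compound 2 to compound 4 (0.39 log units; beyond the scatter) is expected, toward a weaker inhibitor and beyond the scatter. For compound 4 in this assay the estimate is 9000 nM, within 2500 nM to 30000 nM.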

Compound 4, half-maximal inhibitory concentration: 360 nM
Compound 4: middle estimate off by 25-fold (1.40 log units), on the high side, outside the stated range (below it).
By their numbers in this assay, from the lowest: compound 4; then compound 1; then compound 2; then compound 3.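

In this assay, for the compounds shown here, the change from 3-chlorobenzyl to methyl on the amide-type nitrogen in a ring gives a 10-fold lower number from compound 2 to compound 4 (1.01 log units; beyond the scatter) and is the first single-place step. With the bromoacrylamide retained, activity at this position therefore does not depend on the 3-chlorophenyl, and the step runs toward a stronger inhibitor when that group leaves. Nothing available accounts for the size of this step.

On these data alone, with only 3-chlorobenzyl and methyl compared at this place, it remains open whether an ethyl group, a longer chain or a chain ending in an amine would continue this direction or reverse it. As far as these compounds go, it also remains open whether the same step would hold with the bromoacrylamide placed as in compound 1.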